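Swapping the halogenated phenyl arm on a shared core

The source may report more compounds than this note shows. Statements on the series, on what has been measured and on what is new or still open speak of the compounds shown alone.

Measured so far:
compound 2, `C=CCn1c(=O)/c(=C\c2ccccc2Cl)[nH]c(=O)/c1=C\c1ccccc1OC`: 5300 nM
compound 1, `COc1ccccc1/C=c1/[nH]c(=O)/c(=C\c2cccc(Cl)c2Cl)[nH]c1=O`: "not active" (no number reported)

Among the compounds with values here, compound 2 is the only compound here with a number. In a functional assay on A549 cells (Homo sapiens) for cytotoxicity, read by CCK-8 assay, with a stated time of 72 h (on this read-out higher numbers stand for weaker inhibition and lower numbers for stronger inhibition), compound 2 gives 5300 nM. Compound 1 was also tested in this assay, but for compound 1 the result is reported only as "not active" (no number reported), without a number, so it gives no scale for comparison.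

Compound 3, `C=CCn1c(=O)/c(=C\c2cc(Br)ccc2F)[nH]c(=O)/c1=C\c1ccccc1OC`, has not yet been measured. It keeps the shared core of compound 2 and differs in one place: 5-bromo-2-fluorophenyl in place of 2-chlorophenyl on a double-bonded chain carbon bound to an aromatic carbon. Within the data shown here, no pair of measured compounds shows what such a swap does on this core, so there is no measured step to lean on.

With nothing to suggest a direction, the expectation is that the change leaves the potency within the usual scatter, and the step from compound 2 to compound 3 is estimated at a 1.1-fold lower number from compound 2 to compound 3 (0.03 log units; within the scatter) in this assay. Compound 3 is therefore expected at about 5000 nM, with a range from 1500 nM to 16000 nM.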

Compound 3, half-maximal inhibitory concentration: "not active" (no number reported)
Nothing numeric was reported for compound 3, so the estimate cannot be set against anything.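

In this assay, within the data shown here, compound 3 gives "not active" (no number reported) and so has no number to set against compound 2, which means no step between the two can be read. Nothing measured here bears on this result. The compounds shown leave open how far 5-bromo-2-fluorophenyl in place of 2-chlorophenyl shifts the potency on this shared core.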